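Benzyl to Methyl on the Oxygen-Linked Ester Chain

A few compounds are considered here, and "the series" means these few. Any claim that something is new, unique, unknown or untested is made for them only; others in the source may bear on it.

Compound 1 `CCOC(=O)C(C)CN1C(=O)c2ccccc2C1=O`: 41%
Compound 2 `CCOC(=O)C(C)(C)ON1C(=O)c2ccccc2C1=O`: 95%
Compound 3 `CCOC(=O)C(Cc1ccccc1)ON1C(=O)c2ccccc2C1=O`: 70%

In a functional assay on the whole organism for inhibition, with Lepidium sativum as the target, tested at 100 ppm (on this read-out lower numbers stand for less inhibition of growth and higher numbers for more inhibition of growth at the one concentration tested), compound 3 gives 70%, the second highest of the three numbers: compound 2 lies above it by a gap beyond the scatter, and compound 1 lies below it, also beyond the scatter. Compound 4 `CCOC(=O)C(C)ON1C(=O)c2ccccc2C1=O` has not been measured. It differs from compound 3 in one place: hydrogen in place of phenyl on a saturated chain carbon, two bonds along the chain from a carbonyl carbon and an oxygen on an unsaturated carbon. Within the data shown here, no pair of measured compounds shares this change, so no measured step guides it directly. Compound 2, with the smaller groups on the same chain carbon, gives 95%, and on that basis a modest upward step in this assay is expected, possibly no larger than the scatter. Compound 4 is therefore estimated at 80%, within 55% to 98%, an expected step of a number 10 percentage points higher from compound 3 to compound 4 (within the scatter).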

Compound 4, percent growth inhibition at one concentration: 100%
For compound 4 the middle estimate is 20 percentage points below the measured one, outside the stated range (above it).
By their numbers in this assay, from the lowest: compound 1; then compound 3; then compounds 2 and 4 (each within the scatter of the next).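

Benzyl to methyl on this saturated chain carbon gives a number 30 percentage points higher from compound 3 to compound 4 (beyond the scatter) in this assay, so this position responds to the change in the chain. Hydrogen in place of methyl on the same carbon gives a number 5 percentage points higher from compound 2 to compound 4 (within the scatter) and so separates compound 2 from compound 4 by no more than the scatter. Nothing available explains either step.

As far as these compounds go, whether an ethyl or a longer chain on this carbon stays with compound 4 or moves towards compound 3 remains open. So does the effect of a carboxylic acid in place of the ethyl ester.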